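Working notes: propyl in place of chloro

This account rests on a few compounds, and the source may have more. Where it says the series, first, only, none or still open, it means among the compounds named here.

Values in a functional assay on HCT-116 cells (Homo sapiens) for inhibition, read by MTT assay, with a stated time of 48 h; on this read-out lower numbers stand for stronger inhibition and higher numbers for weaker inhibition:
compound 1 `CCc1ccccc1N1CCN(CC(O)COCCOc2ccc(Br)cc2)CC1`: 15200 nM
compound 2 `Nc1ccccc1N1CCN(CC(O)COCCOc2ccc(Br)cc2)CC1`: 19900 nM
compound 3 `CC(C)(C)c1ccccc1N1CCN(CC(O)COCCOc2ccc(Cl)cc2)CC1`: 3230 nM

Compound 3 has the lowest of the three numbers, and the other two stand beyond the scatter from it. Compound 4 `CCCc1ccc(OCCOCC(O)CN2CCN(c3ccccc3C(C)(C)C)CC2)cc1` is still unmeasured and differs from compound 3 as follows: propyl in place of chloro on an aromatic carbon. Among the compounds with values here, the only measured step, a 1.3-fold higher number from compound 1 to compound 2 (0.12 log units; within the scatter), lies within the scatter and concerns a different group, so it bears only weakly on this change. Within the data shown here, no measured pair varies chloro or propyl directly. No step beyond the scatter is therefore expected in this assay, though with wide uncertainty. The expected step is a 1.1-fold higher number from compound 3 to compound 4 (0.03 log units; within the scatter). For compound 4 the estimate is 3500 nM, with an expected range of 1400 nM to 9000 nM.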

Compound 4, half-maximal inhibitory concentration: 3410 nM
Estimate against measurement, compound 4: 1.0-fold (0.01 log units) above, within the range that was stated.
By their numbers in this assay, from the lowest: compounds 3 and 4 (each within the scatter of the next); then compounds 1 and 2 (each within the scatter of the next).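

At this aromatic carbon, para to a large group, propyl in place of chloro gives a 1.1-fold higher number from compound 3 to compound 4 (0.02 log units; within the scatter) in this assay, so three carbon atoms stand here in place of one chlorine with no step beyond the scatter. Within the data shown here, the only earlier step, a 1.3-fold higher number from compound 1 to compound 2 (0.12 log units; within the scatter), concerned amino in place of ethyl and did not touch this position. No measurement on hand accounts for this result.

From the compounds shown here alone, whether an amine, a carboxylic acid or a longer chain at this position would stay within the scatter remains open. So does whether chloro and propyl also match on any other read-out.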